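A few compounds are considered here, and "the series" means these few. Any claim that something is new, unique, unknown or untested is made for them only; others in the source may bear on it.

Measured in a functional assay on MDA-MB-468 cells (Homo sapiens) for antiproliferative activity, read by MTT assay, with a stated time of 72 h; on this read-out higher numbers stand for weaker inhibition and lower numbers for stronger inhibition:
Compound 1 `COc1cc(-c2nccn2C(C)C)cc(OC)c1OC`: > 100000 nM
Compound 2 `COc1cc(-c2nccn2S(=O)(=O)c2ccccc2)cc(OC)c1OC`: > 100000 nM
Compound 3 `COc1cc(-c2nccn2-c2ccc3cc[nH]c3c2)cc(OC)c1OC`: 1700 nM

Compound 1 stands at the limit of > 100000 nM in this assay, at which 2 of the 3 values shown sit, which is a limit and not a number. Compound 2 shares that limit. Only compound 3 gives a number, 1700 nM.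

Compound 4 `COc1cc(-c2nccn2-c2cccc(C)c2)cc(OC)c1OC` has 3-methylphenyl in place of isopropyl on an aromatic nitrogen. Among the measured compounds shown here, no measured step shows this change directly. Compound 3, at 1700 nM, carries an aromatic group on that nitrogen and suggests that a number can be reached. Compound 2 goes against this pattern. A large gain in this assay is therefore expected, with the estimated step of an at least 20-fold lower number from compound 1 to compound 4 (1.30 log units; beyond the scatter). Compound 4 is expected at 5000 nM, within an estimated range from 800 nM to 40000 nM.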

Compound 4, half-maximal inhibitory concentration: 22600 nM
Estimate against measurement, compound 4: 4.5-fold (0.66 log units) below, and the stated range covers the measured number.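

In this assay, 3-methylphenyl in place of isopropyl on an aromatic nitrogen gives an at least 4.4-fold lower number from compound 1 to compound 4 (0.64 log units; beyond the scatter), the only pair shown that differs in one place. It shows that this nitrogen responds to the change, and that a six-membered aromatic ring of carbon only, with no hydrogen-bond donors, is enough to give a number. Compound 1 stands at a limit, so the size of this step is only a lower bound: the limit of > 100000 nM in this assay, at which 2 of the 4 values shown sit.

The compounds shown leave open whether an amine or a methoxy in place of the methyl on that ring would shift the number further.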